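The compounds below may be only part of what the source reports. "The series", "measured", "known", "first", "only" and "open" are said of these compounds alone.

In an ADME assay on microsomes from liver (Homo sapiens) for metabolic stability (on this read-out higher numbers stand for a longer-lived compound and lower numbers for a shorter-lived compound), compound 2 (`Cn1c(-c2ccc(Cl)cc2)cnc1NC(=O)c1ncc[nH]1`) gives > 4.25 h as a limit of the assay, not a number. Compound 1 (`COc1ccc(-c2cnc(NC(=O)c3ncc[nH]3)n2C)cc1`) gives > 4.25 h as a limit too. Within the data shown here, the only measured step is a step that the two limits leave unreadable from compound 1 to compound 2 and it offers no size to carry over, with the limit of > 4.25 h in this assay, at which 2 of the 2 values shown sit, as the whole of the evidence. Compound 3 (`Cn1c(-c2ccccc2)cnc1NC(=O)c1ncc[nH]1`) differs from compound 2 through hydrogen in place of chloro on an aromatic carbon in this way: hydrogen in place of chloro on an aromatic carbon, para to a large group. No step beyond the scatter is expected in this assay and no direction can be named. The expected step is a step that the limit leaves unreadable from compound 2 to compound 3 on this estimate. Compound 3 is expected at 5 h (estimated range 2.5 h to 10 h).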

Compound 3, half-life: 1.47 h
The estimate for compound 3 lay 3.4-fold (0.53 log units) above the measured number; the whole stated range lies above it.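

In this assay, among these compounds, this place on the six-membered aromatic ring gives the first readable steps: hydrogen in place of chloro gives an at least 2.8-fold lower number from compound 2 to compound 3 (0.46 log units; beyond the scatter), and hydrogen in place of methoxy gives an at least 2.8-fold lower number from compound 1 to compound 3 (0.46 log units; beyond the scatter). Compound 3, without a substituent at this place, is thus the shorter-lived compound against both compound 1 and compound 2. Both steps give only a minimum size, and chloro and methoxy stay unranked, as compound 1 and compound 2 both rest on a limit: the limit of > 4.25 h in this assay, at which 2 of the 3 values shown sit.

Going by these compounds, whether fluoro, methyl or an amine at this place would go with the longer half-life of compound 1 and compound 2 or the shorter one of compound 3 remains open.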